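Fluorophenylamino variants on the shared core: cytotoxicity notes

The source may report more compounds than this note shows. Statements on the series, on what has been measured and on what is new or still open speak of the compounds shown alone.

Measured compounds:
compound 1, `C=C1[C@@H](C/C=C2/C(=O)OC[C@H]2OC(C)=O)[C@]2(C)CC[C@@H](OC(C)=O)[C@@](C)(CO[Si](C)(C)C(C)(C)C)[C@H]2C[C@@H]1O`, 9310 nM
compound 2, `C=C1[C@@H](OC(C)=O)C[C@@H]2[C@](C)(CO[Si](C)(C)C(C)(C)C)[C@H](OC(C)=O)CC[C@@]2(C)[C@@H]1C[C@@H](Nc1ccccc1F)C1=CCOC1=O`, 3710 nM
compound 3, `C=C1[C@@H](OC(C)=O)C[C@@H]2[C@](C)(COC=O)[C@H](OC(C)=O)CC[C@@]2(C)[C@@H]1C[C@@H](Nc1ccc(Br)cc1)C1=CCOC1=O`, 13200 nM

All three were run in a functional assay on HT-29 cells (Homo sapiens) for cytotoxicity, read by sulforhodamine B assay; on this read-out lower numbers stand for stronger inhibition and higher numbers for weaker inhibition. Compound 1 gives 9310 nM, compound 3 gives 13200 nM, and compound 2 gives 3710 nM. Compound 2 holds the lowest number of the three, and its gaps to compound 1 and to compound 3 both lie beyond the scatter, so within this small set it is the most potent. For the measured compounds named here, no pair among the measured compounds differs in only one place, so no single-change step can be read off.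

Compound 4, `C=C1[C@@H](OC(C)=O)C[C@@H]2[C@](C)(CO[Si](C)(C)C(C)(C)C)[C@H](OC(C)=O)CC[C@@]2(C)[C@@H]1C[C@@H](Nc1cccc(F)c1)C1=CCOC1=O`, has not yet been measured. It differs from compound 2 by one change: 3-fluorophenyl in place of 2-fluorophenyl on an amine nitrogen. The two have the same atoms, joined differently; the difference, cut one bond further out, reads (2-fluorophenyl)amino to (3-fluorophenyl)amino. Nothing in the measured set speaks to such a change, so the expectation rests on compound 2 alone. The step of a 1.2-fold higher number from compound 2 to compound 4 (0.08 log units; within the scatter) is expected to fall within the scatter, with no clear direction. Compound 4 is estimated at 4500 nM, with a range from 1800 nM to 12000 nM.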

Compound 4, half-maximal inhibitory concentration: 4520 nM
Estimate against measurement, compound 4: 1.0-fold (0.00 log units) below, within the range that was stated.
By their numbers in this assay, from the lowest: compounds 2 and 4 (each within the scatter of the next); then compounds 1 and 3 (each within the scatter of the next).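

In this assay, 3-fluorophenyl in place of 2-fluorophenyl on an amine nitrogen gives a 1.2-fold higher number from compound 2 to compound 4 (0.09 log units; within the scatter), so no order can be assigned to this pair. For the compounds shown here, this is the first single-change step; the earlier compounds offered none. It shows that, at this amine nitrogen, these two fluorophenyl groups cannot be told apart in this read-out, and no measurement at hand accounts for this result.

Open, on these data alone, is whether a plain phenyl, a chlorophenyl or a methoxyphenyl on the same nitrogen would also stay within the scatter of compound 2. Also open, as far as these compounds go, is whether the same fluorophenyl swap would give a similar step with a free alcohol in place of the silyl ether on the shared core.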